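Toward Compound 4: Swapping the Amine on Compound 3

A few compounds are considered here, and "the series" means these few. Any claim that something is new, unique, unknown or untested is made for them only; others in the source may bear on it.

- compound 1 `CCC(=O)N(c1ccc([N+](=O)[O-])cc1)C1CCCC1N(C)C`: 6 mg/kg
- compound 2 `CCC(=O)N(c1ccc(C#N)cc1)C1CCCC1N(C)C`: 40 mg/kg
- compound 3 `CCNC1CCCC1N(C(=O)CC)c1ccc(Cl)c(Cl)c1`: 2 mg/kg
- compound 4 `C=CCN(C)C1CCCC1N(C(=O)CC)c1ccc(Cl)c(Cl)c1`: not yet measured

In a functional assay on the whole organism for antagonist activity, with Mus musculus as the target (a higher number here means that more compound is needed for the effect, a lower number that less compound is needed), compound 3 gives 2 mg/kg, the lowest of the three numbers. Compound 4 carries allyl(methyl)amino in place of ethylamino on a saturated ring carbon. For the measured compounds named here, the only measured step, a 6.7-fold higher number from compound 1 to compound 2 (0.82 log units; beyond the scatter), is cyano in place of nitro on an aromatic carbon, so it bears only indirectly, showing a modest shift from a different change. Going by the values given here, no measured step covers this amine change. Compound 1, a dimethylamino compound, gives 6 mg/kg, but its aromatic substituent also differs from that of compound 3. The expected change is modest and upward, a 2.0-fold higher number from compound 3 to compound 4 (0.30 log units; within the scatter). For compound 4 the estimated value is 4 mg/kg, with an expected range of 1 mg/kg to 15 mg/kg.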

Compound 4, dose for half-maximal effect: 0.2 mg/kg
The estimate for compound 4 lay 20-fold (1.30 log units) above the measured number, outside the stated range (below it).
By their numbers in this assay, from the lowest: compound 4; then compound 3; then compound 1; then compound 2.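

In this assay, allyl(methyl)amino in place of ethylamino on the saturated ring carbon gives a 10-fold lower number from compound 3 to compound 4 (1.00 log units; beyond the scatter), showing that the amine at this position can move the dose needed, which the earlier step on the aromatic carbon could not show. The change removes the hydrogen-bond donor, adds a double bond and enlarges the group all at once, so the compounds do not separate these features. No evidence on hand accounts for the shift.

On these data alone, whether the double bond matters remains open, and propyl(methyl)amino in the same place would address that. As far as these compounds go, how a pyrrolidine there would compare also remains open.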